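The compounds below may be only part of what the source reports. "The series", "measured", "known", "first", "only" and "open" are said of these compounds alone.

Working notes on the series. Compound 1 `COc1cccc([S+]([O-])c2cccc(N)c2C#N)c1` and compound 2 `Cc1cccc([S+]([O-])c2cccc(N)c2C#N)c1` share one core; compound 3 `Cc1cc(C)cc(S(=O)(=O)c2cccc(F)c2C#N)c1` and compound 4 `COc1cc(C)cc(S(=O)(=O)c2cccc(F)c2C#N)c1` share another, and the difference between the two cores is not broken down here. All readings come from a functional assay on MT4 cells (Homo sapiens) for cytotoxicity; a higher number here means a weaker inhibitor, a lower number a stronger inhibitor.

In this assay compound 1 gives only a limit, > 80000 nM. In this assay compound 2 also gives only a limit, > 200000 nM. The change from compound 2 to compound 1 is methoxy in place of methyl on an aromatic carbon. The step it made, a step that the two limits leave unreadable from compound 2 to compound 1, cannot be sized because both ends sit at limits, the limit of > 80000 nM in this assay, at which 1 of the 3 values shown sits, and (the limit of > 200000 nM in this assay, at which 2 of the 3 values shown sit).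

In this assay compound 3 gives only a limit, > 200000 nM. Compound 4 has not been measured in this assay. Its change from compound 3 is methoxy in place of methyl on an aromatic carbon. This is the same kind of change as from compound 2 to compound 1, not the same, as in compound 4 the place is also meta to a methyl group (1 heavy atom).

For compound 4 the step from compound 3 in this assay is expected to be a step that the limit leaves unreadable from compound 3 to compound 4, beside the unreadable earlier one. That expectation rests on compound 1, compound 2 and compound 3 all giving only limits, two of them at the limit of > 200000 nM in this assay, at which 2 of the 3 values shown sit, with the same kind of change leaving compound 1 at a limit as well. Compound 4 is therefore expected in this assay at about 250000 nM, most likely again reported as a limit, with a range from 100000 nM to 600000 nM.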

Compound 4, half-maximal inhibitory concentration: 8000 nM
The estimate for compound 4 lay 31-fold (1.49 log units) above the measured number; the whole stated range lies above it.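

In this assay, methoxy in place of methyl on an aromatic carbon gives an at least 25-fold lower number from compound 3 to compound 4 (1.39 log units; beyond the scatter), so on the core of compound 3 this change goes with a large shift, and compound 4 is the only compound shown with a measured number rather than a limit. The same kind of change on the core of compound 2 cannot be read, since both ends of that step are limits, so the compounds shown do not establish that the result carries from one core to the other, nor that it fails to carry. The comparison is further confounded by the differing cores and by the place in compound 4 also being meta to a methyl group, and the size of the new step is itself tied to a limit at its starting end: the limit of > 200000 nM in this assay, at which 2 of the 4 values shown sit.

From the compounds shown here alone, what an ethoxy group or an amine would give at this same place on the core of compound 3 stays open. Also open, going by these compounds, is whether methoxy owes its result to the accompanying methyl group, which only a pair on the core of compound 1 carrying that methyl group could address.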